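Methyl for chloro on the pendant aryl ring: cytotoxicity notes

The source may hold more compounds than are shown below. What is called first, only, known or untested is meant among the compounds shown, and "the series" means these compounds.

Measured so far:
compound 1 `COc1ccc(-c2cn3nc(Cl)sc3n2)cc1` — > 250000 nM in a functional assay on HeLa cells (Homo sapiens) for cytotoxicity, with a stated time of 72 h; on this read-out higher numbers stand for weaker inhibition and lower numbers for stronger inhibition
compound 2 `Clc1ccc(Cc2nn3c(Br)c(-c4ccc(Cl)cc4)nc3s2)cc1` — > 250000 nM in this assay

In this assay compound 1 returns > 250000 nM, which is a limit of the assay and not a number. Compound 2 likewise returns > 250000 nM, again a limit. Compound 2 therefore stands where every value shown stands, namely at the limit of > 250000 nM in this assay, at which 2 of the 2 values shown sit. Among the measured compounds shown here, no step between measured compounds can be drawn from these two limits, and the numbers do not separate compound 1 from compound 2.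

Compound 3 `Cc1ccc(-c2nc3sc(Cc4ccc(Cl)cc4)nn3c2Br)cc1` differs from compound 2 in one place: methyl in place of chloro on an aromatic carbon. For the measured compounds named here, no measured step bears on this exchange. Because compound 2 sits at the limit of > 250000 nM in this assay, at which 2 of the 2 values shown sit, the expected step that the limit leaves unreadable from compound 2 to compound 3 is none beyond the scatter. Compound 3 is accordingly estimated at 300000 nM, with a range from 100000 nM to 1000000 nM, and is expected to be reported once more as a limit.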

Compound 3, half-maximal inhibitory concentration: > 250000 nM
Compound 3: no number, only a limit; the forecaster's own chance of this, stated with the estimate: 85%; the middle value is on the limit's open side.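

No step can be read from compound 2 to compound 3, methyl in place of chloro on an aromatic carbon, since both results are limits of the assay and not numbers: the limit of > 250000 nM in this assay, at which 3 of the 3 values shown sit. The compounds shown leave open whether this series gives any numerical value in this assay.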